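This account rests on a few compounds, and the source may have more. Where it says the series, first, only, none or still open, it means among the compounds named here.

Measured compounds in a functional assay on MDA-MB-231 cells (Homo sapiens) for antiproliferative activity, read by MTT assay, with a stated time of 48 h; on this read-out higher numbers stand for weaker inhibition of growth and lower numbers for stronger inhibition of growth:

Compound 1, `COc1ccc(/C=C2\Cc3c(cc(OC)c(OC)c3OC)C2=O)cc1O`: in this assay compound 1 gives 570 nM.
Compound 2, `COc1ccc(/C=C2\Cc3c(cc(OC)c(OC)c3OC)C2=O)cc1[N+](=O)[O-]`: in this assay compound 2 gives 3490 nM.
Compound 3, `COc1ccc(/C=C2\Cc3cc(OC)c(OC)c(OC)c3C2=O)cc1O`: for compound 3 only a limit of the assay is known, > 10000 nM.

Compound 1 and compound 3 are built from the same atoms joined differently; how the two cores differ is not broken down here. Within the core of compound 1, one change has been measured: compound 2 differs from compound 1 by nitro in place of hydroxy on an aromatic carbon, and in this assay the step is a 6.1-fold higher number from compound 1 to compound 2 (0.79 log units; beyond the scatter).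

Compound 4, `COc1ccc(/C=C2\Cc3cc(OC)c(OC)c(OC)c3C2=O)cc1[N+](=O)[O-]`, is not yet measured. Going by the values given here, it differs from compound 3 by nitro in place of hydroxy on an aromatic carbon, the same change as the one from compound 1 to compound 2, here made on the core of compound 3. The two descriptions of the place of the change agree word for word.

What is known of compound 3 in this assay is the limit of > 10000 nM in this assay, at which 1 of the 3 values shown sits, so the starting point for compound 4 is itself a limit and not a number. The step that the limit leaves unreadable from compound 3 to compound 4 is expected to run in the same direction as the measured step, and that expectation rests on a 6.1-fold higher number from compound 1 to compound 2 (0.79 log units; beyond the scatter). Compound 4 is therefore expected to give 40000 nM, with a plausible range from 10000 nM to 150000 nM, and it is likely that this assay will again report only a limit.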

Compound 4, concentration for 50% growth inhibition: > 10000 nM
Compound 4: only a limit was reported (the forecaster's own chance of this, stated with the estimate: 85%); the middle value is on the limit's open side.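

In this assay compound 4 gives > 10000 nM as a limit of the assay. Going by these compounds alone, compound 3 also stands only at a limit, so no step from compound 3 to compound 4 can be read: the limit of > 10000 nM in this assay, at which 2 of the 4 values shown sit.

From the compounds shown here alone, whether the change of nitro in place of hydroxy on an aromatic carbon repeats a 6.1-fold higher number from compound 1 to compound 2 (0.79 log units; beyond the scatter) on the core of compound 3 stays open.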